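The source may report more compounds than this note shows. Statements on the series, on what has been measured and on what is new or still open speak of the compounds shown alone.

Within the data shown here, compound 3 `FC(F)(F)CCCSc1nsnc1[C@H]1CN2CCC[C@@H]1C2` gives 1.8 mg/kg in a functional assay on the whole organism with Mus musculus as the target, in the writhing test (a higher number here means that more compound is needed for the effect, a lower number that less compound is needed), and so holds the highest number of the three measured so far, above compound 1 `FC(F)(F)CCCSc1nsnc1C1CN2CCCC1C2` with 0.1 mg/kg and compound 2 `FC(F)(F)CCCCSc1nsnc1[C@@H]1CN2CCC[C@@H]1C2` with 0.07 mg/kg as well. Compound 4 `FC(F)(F)CCCSc1nsnc1[C@H]1CN2CCC[C@H]1C2` is built from the same pieces as compound 3, and the change is this: the two compounds have the same atoms and bonds; at least one stereo element is drawn with a configuration in one of them and without one in the other: 1 of 3 stereo elements differ; a stereocentre at a saturated ring carbon is drawn S in compound 3 and R in compound 4 and nothing else. Among the measured compounds shown here, the only measured step bearing on this is an 18-fold higher number from compound 1 to compound 3 (1.26 log units; beyond the scatter) which is large and comes with the fact that one of compounds 1 and 3 is drawn with a defined configuration and the other without, at the place where they differ as its only visible reason. Configuration alone can therefore shift the numbers in this assay strongly, so a clear fall is expected for compound 4, though probably not all the way to the level of compound 1. Compound 4 is estimated at 0.4 mg/kg within a range of 0.06 mg/kg to 2.5 mg/kg on this expectation. That estimate means an expected 4.5-fold lower number from compound 3 to compound 4 (0.65 log units; beyond the scatter) in this assay overall.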

Compound 4, dose for half-maximal effect: 0.1 mg/kg
Beside the measured number, compound 4's estimate is 4.0-fold (0.60 log units) above it; the measured number falls inside the stated range.
By their numbers in this assay, from the lowest: compounds 2, 1 and 4 (each within the scatter of the next); then compound 3.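

Changing one stereocentre at a saturated ring carbon, from S in compound 3 to R in compound 4, gives an 18-fold lower number from compound 3 to compound 4 (1.26 log units; beyond the scatter) in this assay. The earlier step set a defined form against one drawn without configuration, whereas this pair has both forms defined, so the large shift follows this single centre alone. The other new step reads no change at the digits printed from compound 1 to compound 4 (within the scatter), which places compound 4 level with compound 1.

On these data alone, it remains open whether this single centre matters as much when a nitrile replaces the trifluoromethyl at the chain end.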